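The compounds below may be only part of what the source reports. "The series", "measured", "known", "first", "only" and "open" are said of these compounds alone.

Measured so far in a functional assay on HepG2 cells (Homo sapiens) for antiproliferative activity, read by XTT assay, with a stated time of 72 h; on this read-out lower numbers stand for stronger inhibition and higher numbers for weaker inhibition:
compound 1 `COc1ncnc2c1c(-c1ccsc1)cn2[C@@H]1O[C@H](CO)[C@@H](O)[C@H]1O`: 430 nM
compound 2 `CSc1ncnc2c1c(-c1ccccc1)cn2[C@@H]1O[C@H](CO)[C@@H](O)[C@H]1O`: > 20000 nM (a limit)
compound 3 `COc1nc(N)nc2c1c(-c1ccccc1)cn2[C@@H]1O[C@H](CO)[C@@H](O)[C@H]1O`: > 20000 nM (a limit)

Compound 1 gives a numerical value in this assay, 430 nM. For compound 2 this assay reports only a limit, > 20000 nM. For compound 3 it likewise reports only a limit, > 20000 nM. Compound 3 therefore stands at the limit of > 20000 nM in this assay, at which 2 of the 3 values shown sit, with no number of its own to set against compound 1.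

Compound 4 `COc1ncnc2c1c(-c1ccccc1)cn2[C@@H]1O[C@H](CO)[C@@H](O)[C@H]1O` has not been measured. It differs from compound 3 in one place: hydrogen in place of amino on an aromatic carbon. For the measured compounds named here, no measured pair covers this change, so its size is not known from the series. Compound 1 carries hydrogen at that aromatic carbon and gives a number, whereas compound 3 with the amino group stays at the limit; compound 1 differs from compound 4 elsewhere as well, so that comparison is only a hint. The expectation is that compound 4 returns a numerical value, estimated at 1000 nM with a range of 200 nM to 10000 nM. That estimate means an expected step of an at least 20-fold lower number from compound 3 to compound 4 (1.30 log units; beyond the scatter) toward stronger inhibition, a large one, though measured from a limit its size stays uncertain.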

Compound 4, half-maximal inhibitory concentration: > 20000 nM
Compound 4 was reported as a limit (the forecaster's own chance of this, stated with the estimate: 25%); at least 20-fold (1.30 log units) between middle value and limit.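

Hydrogen in place of amino on the aromatic carbon between two ring nitrogen atoms does not bring compound 4 off the limit in this assay, and the steps to compound 4 from compound 2 and compound 3 cannot be read, as both ends are limits: the limit of > 20000 nM in this assay, at which 3 of the 4 values shown sit.

For the compounds shown here, the one readable change lies at the other place, phenyl in place of thiophen-3-yl, with an at least 46-fold higher number from compound 1 to compound 4 (1.66 log units; beyond the scatter). Compound 4 shares the hydrogen and the methoxy group with compound 1, so hydrogen at that carbon does not by itself give a number; among these compounds, only compound 1 with thiophen-3-yl does.

On these data alone, how far compound 2, compound 3 and compound 4 differ beyond the limit stays open. Also open, as far as these compounds go, is whether furan-3-yl or thiophen-2-yl would keep a number, and whether amino or methylsulfanyl would do so alongside thiophen-3-yl.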